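This account rests on a few compounds, and the source may have more. Where it says the series, first, only, none or still open, it means among the compounds named here.

Working notes on the series. In an ADME assay on CHO cells (Cricetulus griseus) for cytotoxicity, read by MTT assay, with a stated time of 72 h (on this read-out lower numbers stand for higher toxicity in this test and higher numbers for lower toxicity in this test), compound 1 (`CCOC(=O)c1c(-c2ccc(F)cc2)oc2ccc(OCCN3C(=O)C(=O)c4cc(F)ccc43)cc12`) gives 64000 nM. Compound 2 (`CCOC(=O)c1c(-c2ccc(OC)cc2)oc2ccc(OCCCN3C(=O)C(=O)c4cc(F)ccc43)cc12`) gives 64000 nM, level with compound 1 at the digits shown and so within the scatter of it. Going by the values given here, these two readings are all the series offers so far, and they differ in more than one place, so no single-place step has been measured.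

Compound 3 (`CCOC(=O)c1c(-c2ccc(OC)cc2)oc2ccc(OCCCCN3C(=O)C(=O)c4ccccc43)cc12`) has not yet been measured. Its difference from compound 2 is as follows: a group of 12 heavy atoms (9 carbon, 1 nitrogen, 2 oxygen; one five-membered non-aromatic ring with 1 hetero atom, one six-membered aromatic ring of carbon only) in place of a group of 12 heavy atoms (8 carbon, 1 nitrogen, 2 oxygen, 1 fluorine; one five-membered non-aromatic ring with 1 hetero atom, one six-membered aromatic ring of carbon only), on a saturated chain carbon, three bonds along the chain from an oxygen on an aromatic ring. Both groups carry no net charge, and each holds a five-membered non-aromatic ring with 1 hetero atom and a six-membered aromatic ring of carbon only.

In this assay, the expectation is no step beyond the scatter, in either direction. This rests only on the level readings of compound 1 at 64000 nM and compound 2 at 64000 nM, and it remains a weak basis. The expected change is a 1.1-fold lower number from compound 2 to compound 3 (0.03 log units; within the scatter). For compound 3 the estimated value is 60000 nM, with an expected range from 28000 nM to 110000 nM.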

Compound 3, half-maximal cytotoxic concentration: 256000 nM
The estimate for compound 3 lay 4.3-fold (0.63 log units) below the measured number, and the stated range ends below it.
By their numbers in this assay, from the lowest: compounds 1 and 2 (each within the scatter of the next); then compound 3.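

In this assay the change on a saturated chain carbon, three bonds along the chain from an oxygen on an aromatic ring, gives a 4.0-fold higher number from compound 2 to compound 3 (0.60 log units; beyond the scatter), so this place is the first in the series shown to move the read-out beyond the scatter, in the direction of lower toxicity in this test. The leaving group holds fluorine and the entering group holds none; the two match in heavy-atom count, rings, double bonds outside aromatic rings, hydrogen-bond acceptors and net charge, and they differ in their carbon and fluorine counts. No measurement at hand bears on what lies behind this step.

The step is a single reading of a whole-group exchange, and no compound shown separates the loss of fluorine from the difference in carbon count, so neither can be credited with the shift on its own. On these data alone, what a chlorine in place of the fluorine, or a longer chain carrying the same group, would give in this assay stays open, as does whether the same exchange has a like effect with the 4-fluorophenyl group of compound 1 in place of the methoxyphenyl group.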